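The source may report more compounds than this note shows. Statements on the series, on what has been measured and on what is new or still open speak of the compounds shown alone.

Compound 1 `Cc1ccc(N2C(=O)C/C(=C\c3cccc(C(=O)Nc4cccc(F)c4)c3)C2=O)cc1` gives 96900 nM in an ADME assay on SW480 cells (Homo sapiens) for cytotoxicity, read by MTT assay, with a stated time of 72 h; on this read-out higher numbers stand for weaker inhibition and lower numbers for stronger inhibition.
Compound 2 `CCCCCN1C(=O)C/C(=C\c2cccc(C(=O)Nc3cccc(F)c3)c2)C1=O` reaches only the assay limit, > 100000 nM.
Compound 3 `Cc1cccc(NC(=O)c2cccc(/C=C3\CC(=O)N(c4ccccc4)C3=O)c2)c1` likewise reaches only the assay limit, > 100000 nM.

Within the data shown here, compound 1 thus holds the only actual number in this set; the other two values are limits, as the limit of > 100000 nM in this assay, at which 2 of the 3 values shown sit, shows. Among the measured compounds shown here, the one measured step, an at least 1.0-fold higher number from compound 1 to compound 2 (0.01 log units; that floor lies within the scatter), stays within the scatter. Compound 4 `CCc1cccc(NC(=O)c2cccc(/C=C3\CC(=O)N(c4ccc(C)cc4)C3=O)c2)c1` differs from compound 1 by ethyl in place of fluoro on an aromatic carbon. For the measured compounds named here, no measured step touches this ring; the single step measured changes the group on the ring nitrogen and does not move beyond the scatter. The expected step is therefore none beyond the scatter, a 1.0-fold higher number from compound 1 to compound 4 (0.01 log units; within the scatter). Compound 4 is estimated at 100000 nM, between 50000 nM and 200000 nM, with a real chance that only a limit is reported.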

Compound 4, half-maximal inhibitory concentration: 65300 nM
For compound 4 the middle estimate is 1.5-fold (0.19 log units) above the measured one, and the stated range covers the measured number.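

In this assay, among these compounds, the change from 3-fluorophenyl to 3-ethylphenyl gives a 1.5-fold lower number from compound 1 to compound 4 (0.17 log units; within the scatter), the first step in this set with a real number at both ends. At this place on the aromatic ring, fluoro and ethyl therefore cannot be told apart, and compound 4 still gives a number rather than a limit. Such numbers remain scarce: the limit of > 100000 nM in this assay, at which 2 of the 4 values shown sit.

On these data alone, whether an amine or a carboxylic acid at this place would move the number beyond the scatter stays open. As far as these compounds go, it is also open whether ethyl would give the same result with pentyl on the ring nitrogen.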